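The compounds below may be only part of what the source reports. "The series", "measured", "known", "first", "only" and "open" are said of these compounds alone.

Measured so far in an assay on cells for inhibition of cytochrome P450 11B2, mitochondrial (Homo sapiens), read by HPLC, with a stated time of 90 min; a lower number here means a stronger inhibitor, a higher number a weaker inhibitor:
compound 1, `CC(C)c1ncncc1-c1nc2cc(F)c(F)cc2n1C1CC1`, 5 nM
compound 2, `N#Cc1ncncc1-c1nc2cc(F)c(F)cc2n1C1CC1`, 13 nM
compound 3, `Fc1cc2nc(-c3cncnc3NCCC(F)(F)F)n(C3CC3)c2cc1F`, 3 nM

Among these three, compound 3 gives the lowest number in this assay. Its nearest neighbour is compound 1, and the step of a 1.7-fold lower number from compound 1 to compound 3 (0.22 log units; within the scatter) lies within the scatter, so these two cannot be ordered. The step of a 4.3-fold lower number from compound 2 to compound 3 (0.64 log units; beyond the scatter) lies beyond the scatter, as does a 2.6-fold higher number from compound 1 to compound 2 (0.41 log units; beyond the scatter).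

Compound 4, `CC(F)(F)c1ncncc1-c1nc2cc(F)c(F)cc2n1C1CC1`, is not yet measured. The change from compound 3 is 1,1-difluoroethyl in place of (3,3,3-trifluoropropyl)amino on an aromatic carbon. Going by the values given here, two measured steps bear on it: compound 1, which carries a small branched alkyl group at the same place, sits close to compound 3, with a 1.7-fold lower number from compound 1 to compound 3 (0.22 log units; within the scatter); compound 2, which carries a cyano group there, sits further away, with a 4.3-fold lower number from compound 2 to compound 3 (0.64 log units; beyond the scatter). Compound 4 resembles compound 1 more than compound 2 in what it carries at this place, so a number near that of compound 1 is expected. The expected step of a 2.0-fold higher number from compound 3 to compound 4 (0.30 log units; within the scatter) is estimated to be a slightly higher number, probably within the scatter. Compound 4 is thus expected to give 6 nM in this assay, in the range 2.5 nM to 15 nM.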

Compound 4, half-maximal inhibitory concentration: 50 nM
Estimate against measurement, compound 4: 8.3-fold (0.92 log units) below, and the stated range ends below it.
By their numbers in this assay, from the lowest: compounds 3 and 1 (each within the scatter of the next); then compound 2; then compound 4.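

In this assay, the place on the aromatic carbon next to the ring nitrogen does not treat 1,1-difluoroethyl as it treats isopropyl, with a 10-fold higher number from compound 1 to compound 4 (1.00 log units; beyond the scatter) between two groups that carry no hydrogen-bond donor or acceptor. The new group also falls behind cyano, with a 3.8-fold higher number from compound 2 to compound 4 (0.59 log units; beyond the scatter), so what this place tolerates does not follow the resemblance between alkyl groups alone. The spread at this one place now reaches a 17-fold higher number from compound 3 to compound 4 (1.22 log units; beyond the scatter) and compound 4 is the weakest of the four, all its steps lying beyond the scatter.

Open, going by these compounds, is whether the fluorine atoms or some other feature of 1,1-difluoroethyl goes with this step, which ethyl, trifluoromethyl or a plain propylamino chain at the same place would help separate. No measurement given here explains the step.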